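This account rests on a few compounds, and the source may have more. Where it says the series, first, only, none or still open, it means among the compounds named here.

Compound 2 `CCCN1CCc2c(cccc2Oc2ncccc2NC(=O)Nc2ccc(OC(F)(F)F)cc2)C1` carries a propyl group on the ring nitrogen of the shared core, and in an assay on HEK293 cells for displacement of a labelled ligand from P2Y purinoceptor 1 (Homo sapiens), read by scintillation counting, with a stated time of 1 h (on this read-out lower numbers stand for stronger inhibition and higher numbers for weaker inhibition), compound 2 gives 620 nM, the highest of the three numbers recorded. Its closest neighbour is compound 3 `CC(C)N1CCc2c(cccc2Oc2ncccc2NC(=O)Nc2ccc(OC(F)(F)F)cc2)C1`, which in this assay gives 560 nM; the two differ by a 1.1-fold lower number from compound 2 to compound 3 (0.04 log units; within the scatter), a gap inside the scatter. Far from both stands compound 1 `CC(C)(C)CN1CCc2c(cccc2Oc2ncccc2NC(=O)Nc2ccc(OC(F)(F)F)cc2)C1`, with 11 nM in this assay: moving from it to compound 2 costs a 56-fold higher number from compound 1 to compound 2 (1.75 log units; beyond the scatter), and to compound 3 costs a 51-fold higher number from compound 1 to compound 3 (1.71 log units; beyond the scatter).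

Compound 4 `CC(C)(C)CCN1CCc2c(cccc2Oc2ncccc2NC(=O)Nc2ccc(OC(F)(F)F)cc2)C1` is the unmeasured member. Relative to compound 2 the change is tert-butyl in place of methyl on a saturated chain carbon, two bonds along the chain from an amine nitrogen in a ring, so the chain grows from propyl to 3,3-dimethylbutyl. Within the data shown here, the step that bears on it is the reverse of the one from compound 1 to compound 2, where losing the terminal branch raised the number by a 56-fold higher number from compound 1 to compound 2 (1.75 log units; beyond the scatter); here the branch is restored, one bond further out. Among the measured compounds shown here, the same large direction is therefore expected, a marked fall in the number, perhaps tempered somewhat by the longer chain, since no measured pair tests that extra carbon. Compound 4 is expected to show a step of a 16-fold lower number from compound 2 to compound 4 (1.19 log units; beyond the scatter) in this assay. Compound 4 is thus estimated at 40 nM, within a range from 8 nM to 200 nM.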

Compound 4, inhibition constant: 190 nM
The estimate for compound 4 lay 4.8-fold (0.68 log units) below the measured number, and the stated range covers the measured number.
By their numbers in this assay, from the lowest: compound 1; then compound 4; then compounds 3 and 2 (each within the scatter of the next).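

Set against the propyl chain in this assay, the tert-butyl end on the chain does pay, but only in part: the change gives a 3.3-fold lower number from compound 2 to compound 4 (0.51 log units; beyond the scatter), and against the branched isopropyl group the result is much the same, with a 2.9-fold lower number from compound 3 to compound 4 (0.47 log units; beyond the scatter). The group placed on the amine nitrogen in the ring is therefore not limited to an all-or-nothing choice between the low number of compound 1 and the high numbers of compounds 2 and 3, since compound 4 lands clearly apart from both. What counts is also where the tert-butyl sits along the chain, as moving it one bond further out gives a 17-fold higher number from compound 1 to compound 4 (1.24 log units; beyond the scatter), so the terminal branch alone does not carry the full gain, and nothing in the data at hand accounts for this difference.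

The compounds shown leave open whether a straight pentyl chain on this nitrogen would stand with compound 4, which would separate chain length from the terminal branch. They also leave open how a cyclohexylmethyl group, or a tert-butyl group bound directly to this nitrogen, would compare with compound 1.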